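This account rests on a few compounds, and the source may have more. Where it says the series, first, only, none or still open, it means among the compounds named here.

Compound 1 `CNC(=O)c1cc(Oc2ccc3nc(Nc4ccc(Br)cc4)ncc3c2)ccn1` was tested in a physicochemical assay for solubility, at pH 7; a higher number here means a more soluble compound, a lower number a less soluble compound. In this assay compound 1 gives < 1000 nM, which is a limit of the assay rather than a number. Compound 2 `CNC(=O)c1cc(Oc2ccc3nc(Nc4ccc(OC(F)(F)F)cc4)ncc3c2)ccn1` shares the core of compound 1 and differs from it only by trifluoromethoxy in place of bromo on an aromatic carbon. In this assay compound 2 gives < 1000 nM, again a limit. The step that the two limits leave unreadable from compound 1 to compound 2 therefore has no readable size because of the limit of < 1000 nM in this assay, at which 2 of the 2 values shown sit. Compound 3 `O=C(NCCO)c1cc(Oc2ccc3nc(Nc4ccc(Br)cc4)ncc3c2)ccn1` keeps the bromo group of compound 1 and differs from it by hydroxymethyl in place of hydrogen on a saturated chain carbon bound to an amide-type nitrogen. Going by the values given here, no measured step shows how this change acts in this assay, and the single step present is unreadable. For compound 3 the estimate in this assay is 700 nM, with a range from 200 nM to 2500 nM. The expected step that the limit leaves unreadable from compound 1 to compound 3 is accordingly small, and a limit rather than a number is the likelier outcome.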

Compound 3, solubility: < 1000 nM
Compound 3: only a limit was reported; the forecaster's own chance of this, stated with the estimate: 70%; the middle value does not contradict the limit.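

In this assay compound 3 gives < 1000 nM, again a limit and not a number. Going by these compounds alone, no step between compound 1 and compound 3 can therefore be read: the limit of < 1000 nM in this assay, at which 3 of the 3 values shown sit.

As far as these compounds go, what (2-hydroxyethyl)carbamoyl in place of methylcarbamoyl actually does in this assay stays open.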